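Moving a fluorine around the benzyl ring of a chalcone

The source may hold more compounds than are shown below. What is called first, only, known or untested is meant among the compounds shown, and "the series" means these compounds.

Of the compounds shown here, three have been measured in a functional assay on MIA PaCa-2 cells (Homo sapiens) for inhibition, read by MTT assay, with a stated time of 48 h, tested at 10 uM; a higher number here means more inhibition of growth at the concentration tested, a lower number less inhibition of growth. Compound 1 `COc1ccc(C(=O)/C=C/c2ccc(OCc3cn(Cc4cccc(F)c4)nn3)cc2)cc1` gives 48%. Compound 2 `COc1ccc(C(=O)/C=C/c2ccc(OCc3cn(Cc4ccc(F)cc4)nn3)cc2)cc1`, which differs by 4-fluorophenyl in place of 3-fluorophenyl on a saturated chain carbon bound to an aromatic nitrogen, gives 6%, a drop of a number 42 percentage points lower from compound 1 to compound 2 (beyond the scatter). Compound 3 `O=C(/C=C/c1ccc(OCc2cn(Cc3cccc(F)c3)nn2)cc1)c1ccc([N+](=O)[O-])cc1` carries a different core, differing from compound 1 by nitro in place of methoxy on an aromatic carbon, and in this assay compound 3 gives 32%, a step of a number 16 percentage points lower from compound 1 to compound 3 (beyond the scatter). Compound 4 `O=C(/C=C/c1ccc(OCc2cn(Cc3ccc(F)cc3)nn2)cc1)c1ccc([N+](=O)[O-])cc1` is not yet measured; it differs from compound 3 by 4-fluorophenyl in place of 3-fluorophenyl on a saturated chain carbon bound to an aromatic nitrogen, the same change that separates compound 1 from compound 2, at the same place. Because the step of a number 42 percentage points lower from compound 1 to compound 2 (beyond the scatter) was large, a similar loss is expected for compound 4, about a number 27 percentage points lower from compound 3 to compound 4 (beyond the scatter). Compound 4 is therefore estimated at 5%, with a likely range from -5% to 22%, before its measurement is known.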

Compound 4, percent growth inhibition at one concentration: 44%
Compound 4: the middle estimate sits 39 percentage points below what was measured, and the stated range ends below it.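

In this assay, the change from 3-fluorophenyl to 4-fluorophenyl did not carry over from the core of compound 1 to the core of compound 3; here the result is a number 12 percentage points higher from compound 3 to compound 4 (beyond the scatter), opposite in direction to the earlier loss: the same change on two cores in this assay, a number 42 percentage points lower (beyond the scatter) from compound 1 to compound 2 and a number 12 percentage points higher (beyond the scatter) from compound 3 to compound 4, 54 percentage points apart, beyond the scatter of two such steps. The change from methoxy to nitro likewise depends on which fluorobenzyl group is present, giving a number 38 percentage points higher from compound 2 to compound 4 (beyond the scatter) against the earlier fall: the same change on two cores in this assay, a number 16 percentage points lower (beyond the scatter) from compound 1 to compound 3 and a number 38 percentage points higher (beyond the scatter) from compound 2 to compound 4, 54 percentage points apart, beyond the scatter of two such steps. The two changes therefore do not act independently in these four compounds, but the numbers do not show why, or whether this holds beyond them.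

Going by these compounds, whether an amine or a carboxylic acid in place of nitro would behave like nitro or like methoxy remains open. So does the effect of chlorine in place of fluorine on the benzyl ring.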